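The source may report more compounds than this note shows. Statements on the series, on what has been measured and on what is new or still open speak of the compounds shown alone.

Compound 3 `COc1cc(-c2nn(-c3cccc(NC(=O)Nc4ccc(Cl)c(Cl)c4)c3)cc2-c2ccncc2)ccc1Cl` shows no measurable toxicity in a functional assay on MDA-MB-435 cells (Homo sapiens) for inhibition, read by sulforhodamine B assay, with a stated time of 48 h; on this read-out lower numbers stand for higher toxicity in this test and higher numbers for lower toxicity in this test: its value in this assay is a limit of the assay, > 50000 nM. For the measured compounds named here, the only numerical value among the measured compounds belongs to compound 2 `COc1cc(-c2nn(-c3cccc(NC(=O)Nc4cc(C(F)(F)F)cc(C(F)(F)F)c4)c3)cc2-c2ccncc2)ccc1Cl`, which gives 4460 nM in this assay. Compound 4 will carry a hydroxy group; compound 1 `O=C(Nc1cccc(-n2cc(-c3ccncc3)c(-c3ccc(Cl)c(O)c3)n2)c1)Nc1cccc(C(F)(F)F)c1` already does, and in this assay compound 1 likewise stops at a limit of the assay, > 32500 nM. The change to compound 4 `O=C(Nc1cccc(-n2cc(-c3ccncc3)c(-c3ccc(Cl)c(O)c3)n2)c1)Nc1ccc(Cl)c(Cl)c1` is hydrogen in place of methyl on an oxygen on an aromatic ring. Going by the values given here, no measured pair of this set differs in one place, so no measured step sets a direction. Because compound 3 sits at the limit of > 50000 nM in this assay, at which 1 of the 3 values shown sits, and compound 1 at the limit of > 32500 nM in this assay, at which 1 of the 3 values shown sits, compound 4 is expected to stay at a limit. The expected step is a number no higher from compound 3 to compound 4 (the limit leaves the size open), nothing beyond the scatter. The estimate for compound 4 in this assay is 50000 nM, between 15000 nM and 150000 nM.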

Compound 4, concentration lethal to 50% of the cells: > 32500 nM
Compound 4 ended at the assay's limit; the forecaster's own chance of this, stated with the estimate: 80%; the middle value lies beyond the limit too.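

Compound 1, compound 3 and compound 4 all stand at limits of this assay, and the steps linking compound 4 to compound 3 and to compound 1 cannot be read. The compounds shown leave open whether methoxy to hydroxy changes toxicity in this test at all.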